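From Methyl to Cyclopropyl on the Amide Nitrogen

The source may hold more compounds than are shown below. What is called first, only, known or untested is meant among the compounds shown, and "the series" means these compounds.

Of the compounds shown here, three have been measured in a functional assay on the whole organism with Mus musculus as the target, at a dose of 100 mg/kg by the intraperitoneal route; a higher number here means more inhibition at the dose given (going by the name of the read-out), a lower number less inhibition. Compound 1 `CCN(C)C(=O)/C=C1\CCc2c(F)cc(F)cc21` gives 100%, compound 2 `CNC(=O)/C=C1\CCc2ccc(Br)cc21` gives 0%, and compound 3 `CNC(=O)/C=C1\CCc2ccc(Cl)cc21` gives 16%. Compound 3 thus stands second of the three, with compound 2 nearest and compound 1 far higher. Among the compounds with values here, the only single change measured so far is a number 16 percentage points higher from compound 2 to compound 3 (beyond the scatter), a change on the aromatic ring. Compound 4 `O=C(/C=C1\CCc2ccc(Cl)cc21)NC1CC1` differs from compound 3 by cyclopropyl in place of methyl on an amide-type nitrogen. Within the data shown here, no measured step touches the amide nitrogen, so neither size nor direction of this change in this assay can be read from the data; a small, uncertain step is expected, a number 14 percentage points higher from compound 3 to compound 4 (beyond the scatter). Compound 4 is therefore estimated at 30%, within a wide range from 0% to 70%.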

Compound 4, a percentage reported as inhibition, in the whole organism at one dose (the size of the read-out at that dose, not a potency): 50%
Beside the measured number, compound 4's estimate is 20 percentage points below it; measured number inside the range.
By their numbers in this assay, from the lowest: compound 2; then compound 3; then compound 4; then compound 1.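

In this assay the amide nitrogen proves to be a position that responds: cyclopropyl in place of methyl gives a number 34 percentage points higher from compound 3 to compound 4 (beyond the scatter) with the chloro group and the rest of the molecule unchanged. The aromatic ring is therefore not the only place on the shared core where the read-out moves. Nothing available explains why this step is so large. On these data alone, it remains open whether isopropyl or cyclobutyl on the same nitrogen would give a similar number. Also open, as far as these compounds go, is whether cyclopropyl would give a similar step with bromo on the ring.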